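Benzimidazole Swapped for a Phenoxymethyl Arm on a Pyridine Core

The source may hold more compounds than are shown below. What is called first, only, known or untested is meant among the compounds shown, and "the series" means these compounds.

Measured compounds:
Compound 1, `Cc1cc(C)cc(-c2cncc(-c3nc4cc(C(F)(F)F)ccc4[nH]3)c2N2CCC(N)CC2)c1`, 0.014 nM
Compound 2, `Cc1cc(C)cc(-c2cncc(-c3nc4cc(F)ccc4[nH]3)c2N2CCC(N)CC2)c1`, 0.013 nM

In a functional assay on CHO-K1 cells for agonist activity at somatostatin receptor type 2 (Homo sapiens), read by cAMP accumulation, with a stated time of 30 min (on this read-out higher numbers stand for an effect only at larger amounts of compound and lower numbers for an effect already at smaller amounts), compound 2 gives 0.013 nM, the lowest of the two numbers shown, though its nearest neighbour compound 1 at 0.014 nM lies within the scatter of it, so the two cannot be ordered.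

Compound 3, `Cc1cc(C)cc(OCc2cncc(-c3cc(C)cc(C)c3)c2N2CCC(N)CC2)c1`, carries the change ((3,5-dimethylphenoxy)methyl in place of 5-fluoro-1H-benzimidazol-2-yl on an aromatic carbon). Within the data shown here, the single measured step, a 1.1-fold lower number from compound 1 to compound 2 (0.03 log units; within the scatter), touches only a substituent on the 5-fluoro-1H-benzimidazol-2-yl group and says nothing about removing that group as a whole; the data therefore contain no step that bears directly on this change. The group that leaves brings one hydrogen-bond donor and two aromatic rings, the (3,5-dimethylphenoxy)methyl that enters brings neither donor nor second ring, so a substantial loss is the expected outcome in this assay, with a wide range.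

The expected step is a 77-fold higher number from compound 2 to compound 3 (1.89 log units; beyond the scatter).

Compound 3 is therefore estimated at 1 nM, with a range from 0.05 nM to 30 nM.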

Compound 3, half-maximal effective concentration: 3.7 nM
Estimate against measurement, compound 3: 3.7-fold (0.57 log units) below; measured number inside the range.
By their numbers in this assay, from the lowest: compounds 2 and 1 (each within the scatter of the next); then compound 3.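

In this assay, putting (3,5-dimethylphenoxy)methyl in place of 5-fluoro-1H-benzimidazol-2-yl gives a 280-fold higher number from compound 2 to compound 3 (2.45 log units; beyond the scatter) and so shows that the aromatic carbon ortho to the 4-aminopiperidin-1-yl group is sensitive to the group it carries, which the earlier change on the benzimidazole, a 1.1-fold lower number from compound 1 to compound 2 (0.03 log units; within the scatter), could not reveal. The two groups have the same number of heavy atoms, yet the entering one has one aromatic ring fewer and no hydrogen-bond donor, so this single step bundles several differences and cannot assign the change in the number to any one of them. No measurement shown here accounts for the size of this step.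

The compounds shown leave open whether a group with a donor on this carbon, such as aminomethyl or 1H-indol-2-yl, would bring the number back towards that of compound 2. They also leave open whether the ether oxygen of the arm matters, a question that a 2-(3,5-dimethylphenyl)ethyl group at the same place would address.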